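A few compounds are considered here, and "the series" means these few. Any claim that something is new, unique, unknown or untested is made for them only; others in the source may bear on it.

Compound 1 `CN(Cc1ccccc1)C1CCc2ccsc2CC1` holds the higher of the two numbers recorded in an assay on membranes from brain for displacement of a labelled ligand from Sigma non-opioid intracellular receptor 1 (Cavia porcellus), read by scintillation counting, with a stated time of 120 min; on this read-out higher numbers stand for weaker inhibition and lower numbers for stronger inhibition: compound 1 gives 49 nM, while compound 2 `CN(CCCCc1ccccc1)C1CCc2ccsc2CC1` gives 17 nM, a gap that lies beyond the usual scatter. Compound 3 `CCN(Cc1ccccc1)C1CCc2ccsc2CC1` differs from compound 1 by methyl in place of hydrogen on a saturated chain carbon bound to an amine nitrogen; cut one bond further out, the change reads methyl to ethyl. Among the compounds with values here, no measured pair carries this change, so in this assay a step no larger than the scatter is expected, in either direction. Compound 3 is accordingly estimated at 40 nM, within 15 nM to 120 nM. This expectation corresponds to a step of a 1.2-fold lower number from compound 1 to compound 3 (0.09 log units; within the scatter).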

Compound 3, inhibition constant: 60 nM
For compound 3 the middle estimate is 1.5-fold (0.18 log units) below the measured one, and the stated range covers the measured number.
By their numbers in this assay, from the lowest: compound 2; then compounds 1 and 3 (each within the scatter of the next).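

In this assay, the first single-place step shown here gives a 1.2-fold higher number from compound 1 to compound 3 (0.09 log units; within the scatter) for methyl in place of hydrogen on a saturated chain carbon bound to an amine nitrogen. In this one pair, the added methyl leaves the number within the scatter, so this place tolerates that small extension on the core of compound 1. No data given here account for the size of this step. On these data alone, whether propyl or a longer chain in the same place would also stay within the scatter remains open, as does whether methyl would give a similar step on compound 2.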